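Ketone and hydroxyl analogues of a tribenzyl-protected sugar core

This account rests on a few compounds, and the source may have more. Where it says the series, first, only, none or still open, it means among the compounds named here.

Measured so far:
compound 1, `CC[C@@H]1O[C@H](COCc2ccccc2)[C@@H](OCc2ccccc2)[C@H](OCc2ccccc2)[C@H]1O`, 19800 nM
compound 2, `CCC[C@@H]1O[C@H](COCc2ccccc2)[C@@H](OCc2ccccc2)[C@H](OCc2ccccc2)[C@H]1O`, 18900 nM
compound 3, `C[C@@H]1O[C@H](COCc2ccccc2)[C@@H](OCc2ccccc2)[C@H](OCc2ccccc2)C1=O`

Compound 3 reaches only a limit of the assay and no number: in a functional assay on HeLa cells (Homo sapiens) for antiproliferative activity, read by sulforhodamine B assay (a higher number here means a weaker inhibitor of growth, a lower number a stronger inhibitor of growth), compound 3 gives > 50000 nM.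

Compound 1 and compound 2 share the hydroxyl-bearing core. The change between them is methyl in place of hydrogen on a saturated chain carbon, two bonds along the chain from a saturated ring carbon, and it makes a 1.0-fold lower number from compound 1 to compound 2 (0.02 log units; within the scatter). The two values therefore show no difference that can be read.

The difference between the core of compound 1 and the core of compound 3 is not broken down here; compound 3 carries a carbonyl where compound 1 carries a hydroxyl, with several other points of difference.

Compound 4, `CC[C@@H]1O[C@H](COCc2ccccc2)[C@@H](OCc2ccccc2)[C@H](OCc2ccccc2)C1=O`, has not yet been measured. It differs from compound 3 by methyl in place of hydrogen on a saturated chain carbon bound to a saturated ring carbon. This is the same kind of change as that from compound 1 to compound 2, but not the same: there the place was a saturated chain carbon two bonds along the chain from a saturated ring carbon, here it is a saturated chain carbon bound to a saturated ring carbon.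

The step from compound 3 to compound 4 is expected to be a step that the limit leaves unreadable from compound 3 to compound 4, resting on the flat step from compound 1 to compound 2 and on compound 3 sitting at the limit of > 50000 nM in this assay, at which 1 of the 3 values shown sits. Compound 4 is expected to give about 60000 nM in this assay, between 25000 nM and 150000 nM, most likely again reported only as a limit.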

Compound 4, concentration for 50% growth inhibition: > 50000 nM
Compound 4: only a limit was reported; the forecaster's own chance of this, stated with the estimate: 70%; the middle value does not contradict the limit.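

In this assay compound 4 gives > 50000 nM, which is a limit of the assay and not a number. Compound 3 also stands at a limit, so no step can be read between compound 3 and compound 4: the limit of > 50000 nM in this assay, at which 2 of the 4 values shown sit.

The compounds shown leave open whether methyl in place of hydrogen changes growth inhibition at all on the carbonyl-bearing core.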